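Triazole aryl variation on the spirooxindole series

A few compounds are considered here, and "the series" means these few. Any claim that something is new, unique, unknown or untested is made for them only; others in the source may bear on it.

Measured so far, in an ADME assay on HUVEC cells (Homo sapiens) for antiproliferative activity, read by MTT assay, with a stated time of 48 h; a higher number here means a weaker inhibitor, a lower number a stronger inhibitor:
compound 1 `CCOc1ccccc1-n1nncc1CN1C(=O)C2(C(C#N)=C(N)Oc3c2c2nc4ccccc4nc2c2ccccc32)c2ccccc21`, reported only as the assay limit > 50000 nM.
compound 2 `Cc1ccc(C)c(-n2nncc2CN2C(=O)C3(C(C#N)=C(N)Oc4c3c3nc5ccccc5nc3c3ccccc43)c3ccccc32)c1`, reported only as the assay limit > 50000 nM.
compound 3 `CCc1ccccc1-n1nncc1CN1C(=O)C2(C(C#N)=C(N)Oc3c(N)cc4nc5ccccc5nc4c32)c2ccccc21`, reported only as the assay limit > 50000 nM.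

Among the measured compounds shown here, every value in this assay so far is a limit and not a number, which is what the limit of > 50000 nM in this assay, at which 3 of the 3 values shown sit, records. Compound 3 therefore stands where the other two stand, at the limit, and nothing separates the three on the numbers shown. For the measured compounds named here, the one step within the measured set, a step that the two limits leave unreadable from compound 1 to compound 2, cannot be read, since both ends of it are limits.

Compound 4 `N#CC1=C(N)Oc2c(N)cc3nc4ccccc4nc3c2C12C(=O)N(Cc1cnnn1-c1c(F)cccc1F)c1ccccc12` is not yet measured. It differs from compound 3 by 2,6-difluorophenyl in place of 2-ethylphenyl on an aromatic nitrogen. Going by the values given here, no measured step bears on this change in a readable way: the only step, between compound 1 and compound 2, is unreadable, and the substituent on the aromatic nitrogen has so far made no visible difference at the limit. The expectation is accordingly no step beyond the scatter, with compound 4 most likely reported again as a limit. Compound 4 is expected to give 60000 nM, within 20000 nM to 200000 nM. The step that the limit leaves unreadable from compound 3 to compound 4 is expected to be flat.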

Compound 4, half-maximal inhibitory concentration: > 50000 nM
Compound 4 gave a limit, no number; the forecaster's own chance of this, stated with the estimate: 85%; the middle value lies beyond the limit too.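

No step can be read between compound 3 and compound 4 in this assay, as both values are limits and not numbers: the limit of > 50000 nM in this assay, at which 4 of the 4 values shown sit.
The compounds shown leave open whether any group on the aromatic nitrogen brings a compound to a measurable value in this assay, and how the four compounds compare beyond the limit.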